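The source may report more compounds than this note shows. Statements on the series, on what has been measured and on what is new or still open speak of the compounds shown alone.

Compound 1 `CC1=CC[C@@H]([C@@](C)(O)CCCC(C)(C)NC(=S)N/N=C\c2ccccc2)CC1` gives the lowest of the three numbers measured in a functional assay on PCO3 cells (Homo sapiens) for cytotoxicity, read by sulforhodamine B assay (a lower number here means a stronger inhibitor of growth, a higher number a weaker inhibitor of growth), at 8470 nM. Compound 2 `CC1=CC[C@@H]([C@@](C)(O)CCCC(C)(C)NC(=S)N/N=C\c2ccc(N(C)C)cc2)CC1` gives 13700 nM in this assay, and compound 3 `CC1=CC[C@@H]([C@@](C)(O)CCCC(C)(C)NC(=S)N/N=C\c2ccc([N+](=O)[O-])cc2)CC1` gives 18100 nM. Compound 4 `CC1=CC[C@@H]([C@@](C)(O)CCCC(C)(C)NC(=S)N/N=C\c2ccccc2Cl)CC1` differs from compound 1 by chloro in place of hydrogen on an aromatic carbon. The two measured changes on the same ring read a 1.6-fold higher number from compound 1 to compound 2 (0.21 log units; within the scatter) and a 2.1-fold higher number from compound 1 to compound 3 (0.33 log units; beyond the scatter). Neither shows what chloro does at its place, but both suggest that a single group added to this ring moves the number only a little, if anything upward. The expectation for compound 4 is therefore a step no larger than the scatter, a 1.2-fold higher number from compound 1 to compound 4 (0.07 log units; within the scatter). Compound 4 is estimated at 10000 nM in this assay, with a likely range from 4500 nM to 22000 nM.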

Compound 4, concentration for 50% growth inhibition: 18800 nM
Compound 4: middle estimate off by 1.9-fold (0.27 log units), on the low side; low and high end bracket the measured number.
By their numbers in this assay, from the lowest: compounds 1, 2, 3 and 4 (each within the scatter of the next, the first and the last beyond it).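

In this assay the chloro group, ortho to a large group, gives a 2.2-fold higher number from compound 1 to compound 4 (0.35 log units; beyond the scatter), so this single chlorine atom is enough to move the number past the scatter. The 2-chlorophenyl group cannot be separated from 4-nitrophenyl, at a 1.0-fold higher number from compound 3 to compound 4 (0.02 log units; within the scatter), or from 4-(dimethylamino)phenyl, at a 1.4-fold higher number from compound 2 to compound 4 (0.14 log units; within the scatter), so the three substituted rings read alike here. On these data alone, whether fluoro, methyl or methoxy in the same place would give a similar step remains open, as does the effect of chloro elsewhere on the ring. What lies behind the chloro step also stays unexplained, with no supporting measurement available.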